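This account rests on a few compounds, and the source may have more. Where it says the series, first, only, none or still open, it means among the compounds named here.

In a functional assay on K562 cells (Homo sapiens), read by MTT assay, with a stated time of 72 h (a lower number here means a stronger inhibitor, a higher number a weaker inhibitor), the measured compounds stand as follows:

- Compound 1 `CN(C)c1ncnc2c1c(-c1cc3ccccc3o1)cn2[C@@H]1O[C@H](CO)[C@@H](O)[C@H]1O`: > 20000 nM (a limit)
- Compound 2 `Nc1nc2c(c(-c3ccco3)cn2[C@@H]2O[C@H](CO)[C@@H](O)[C@H]2O)c(=O)[nH]1`: > 20000 nM (a limit)

Neither compound has yielded a number. Compound 2 stands only at a limit of the assay, and its place is given by the limit of > 20000 nM in this assay, at which 2 of the 2 values shown sit. Compound 1 shares that position, so the two cannot be ranked against each other.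

Compound 3 `Nc1nc2c(c(-c3ccsc3)cn2[C@@H]2O[C@H](CO)[C@@H](O)[C@H]2O)c(=O)[nH]1` keeps the shared core of compound 2 and carries thiophen-3-yl in place of furan-2-yl on an aromatic carbon. For the measured compounds named here, no measured pair isolates a change of this kind, so the data give no direct guide to its size. The expectation rests on compound 2, whose reading of > 20000 nM is a limit. No change beyond the usual scatter is expected in this assay, and no direction can be favoured. The expected size is a number no higher from compound 2 to compound 3 (the limit leaves the size open). The assay may well report only a limit again. For compound 3 the estimated value is 20000 nM, with an expected range from 6000 nM to 50000 nM.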

Compound 3, half-maximal inhibitory concentration: 18300 nM
Beside the measured number, compound 3's estimate is 1.1-fold (0.04 log units) above it; the range from low to high includes it.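

In this assay compound 3 gives 18300 nM, the first reading among the compounds shown that is a number and not a limit, so this core can register in this assay with a five-membered aromatic ring at this place. The reading for compound 2 is a limit: the limit of > 20000 nM in this assay, at which 2 of the 3 values shown sit. Thiophen-3-yl in place of furan-2-yl, on an aromatic carbon two ring bonds from the ring nitrogen, gives an at least 1.0-fold lower number from compound 2 to compound 3 (0.03 log units; that floor lies within the scatter), and since one end of this step is a limit, its true size cannot be read.

For the compounds shown here, compound 1 differs from the other two compounds in more than one place, so no step links it to them, and the part played by its core and its ring at this position stays unresolved. On these data alone, it also remains open whether a different group on this aromatic carbon, such as a phenyl ring, or a thiophene ring carrying an amine or a carboxylic acid, would give a number clearly lower than that of compound 3.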